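Swapping methoxy for nitro on the ketone side of compound 1

The compounds below may be only part of what the source reports. "The series", "measured", "known", "first", "only" and "open" are said of these compounds alone.

Compound 1 `COc1ccc(C(=O)/C=C/c2ccc(OCc3cn(Cc4cccc(Br)c4)nn3)cc2)cc1` is the strongest-looking of three measured compounds: in a functional assay on MCF7 cells (Homo sapiens) for inhibition, read by MTT assay, with a stated time of 48 h, tested at 10 uM (on this read-out lower numbers stand for less inhibition of growth and higher numbers for more inhibition of growth at the one concentration tested), compound 1 gives 45%. Compound 2 `COc1ccc(C(=O)/C=C/c2ccc(OCc3cn(Cc4cccc(F)c4)nn3)cc2)cc1` gives 41%, and compound 3 `COc1ccc(C(=O)/C=C/c2ccc(OCc3cn(Cc4ccc(F)cc4)nn3)cc2)cc1` gives 15%. The steps of a number 4 percentage points lower from compound 1 to compound 2 (within the scatter) and a number 30 percentage points lower from compound 1 to compound 3 (beyond the scatter) all concern the benzyl group on the triazole. Compound 4 `O=C(/C=C/c1ccc(OCc2cn(Cc3cccc(Br)c3)nn2)cc1)c1ccc([N+](=O)[O-])cc1` instead alters the far end of the molecule: nitro in place of methoxy on an aromatic carbon. Among the compounds with values here, no measured step touches that position, so the numbers give no direction for this change. The estimate for compound 4 therefore stays near compound 1, expecting no change at the digits printed from compound 1 to compound 4 (within the scatter), with a wide range: compound 4 is expected to give 45%, between 20% and 70%.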

Compound 4, percent growth inhibition at one concentration: 12%
Compound 4: middle estimate off by 33 percentage points, on the high side; measured number below the stated range.
By their numbers in this assay, from the lowest: compounds 4 and 3 (each within the scatter of the next); then compounds 2 and 1 (each within the scatter of the next).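

The far end of the molecule is not a silent position. In this assay, 4-nitrophenyl in place of 4-methoxyphenyl on the carbonyl gives a number 33 percentage points lower from compound 1 to compound 4 (beyond the scatter), so the group on this ring matters for growth inhibition, as the benzyl group on the triazole did. Nothing measured here explains this drop.

This single swap cannot separate losing the methoxy from gaining the nitro. An amine, a hydroxyl or a chlorine at the same place on the core of compound 1 would leave open whether other groups keep the number of compound 1 or lower it.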